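Phenyl to thiophen-2-yl swap on two nucleoside cores

The source may hold more compounds than are shown below. What is called first, only, known or untested is meant among the compounds shown, and "the series" means these compounds.

Compound 1 `Cc1nc(N)c2c(-c3ccccc3)cn([C@@H]3O[C@H](CO)[C@@H](O)[C@H]3O)c2n1` carries a phenyl; compound 2 `Cc1nc(N)c2c(-c3cccs3)cn([C@@H]3O[C@H](CO)[C@@H](O)[C@H]3O)c2n1` carries thiophen-2-yl in its place, the change being (thiophen-2-yl in place of phenyl on an aromatic carbon). In a functional assay on CEM-DNR-bulk cells (Homo sapiens), read by MTT assay, with a stated time of 72 h (a higher number here means a weaker inhibitor, a lower number a stronger inhibitor), compound 1 gives > 20000 nM, a limit of the assay. Compound 2 gives > 20000 nM in this assay, also a limit. The step that the two limits leave unreadable from compound 1 to compound 2 cannot be read, since (the limit of > 20000 nM in this assay, at which 3 of the 3 values shown sit). Compound 3 `CNc1ncnc2c1c(-c1ccccc1)cn2[C@@H]1O[C@H](CO)[C@@H](O)[C@H]1O` has the same atoms as compound 1 joined differently; the difference between the two cores is not broken down here. Compound 3 gives > 20000 nM in this assay, again a limit. Compound 4 `CNc1ncnc2c1c(-c1cccs1)cn2[C@@H]1O[C@H](CO)[C@@H](O)[C@H]1O` is still to be measured; it differs from compound 3 by thiophen-2-yl in place of phenyl on an aromatic carbon, the same change as made from compound 1 to compound 2. The expected step is a step that the limit leaves unreadable from compound 3 to compound 4, which rests on a step that the two limits leave unreadable from compound 1 to compound 2 and on (the limit of > 20000 nM in this assay, at which 3 of the 3 values shown sit). For compound 4 the expected value in this assay is 30000 nM.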

Compound 4, half-maximal inhibitory concentration: > 20000 nM
Compound 4 gave a limit, no number; the forecaster's own chance of this, stated with the estimate: 85%; the middle value is on the limit's open side.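

No step can be read from compound 3 to compound 4, since both values are limits: the limit of > 20000 nM in this assay, at which 4 of the 4 values shown sit. The compounds shown leave open whether thiophen-2-yl in place of phenyl changes activity on either core.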